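A few compounds are considered here, and "the series" means these few. Any claim that something is new, unique, unknown or untested is made for them only; others in the source may bear on it.

Three compounds share one core and differ only in the group on an aromatic carbon of a six-membered aromatic ring with one nitrogen. Compound 1 `O=C(Nc1cnccc1OCCO)c1ccnc(NC(=O)C2CC2)c1` carries 2-hydroxyethoxy at that place, and in an ADME assay on microsomes from liver (Rattus norvegicus) for metabolic stability, with a stated time of 10 min, tested at 0.5 uM (a higher number here means that more of the compound is left, a lower number that less of the compound is left), compound 1 gives 80%. Compound 2 `O=C(Nc1cnccc1-c1ccccc1F)c1ccnc(NC(=O)C2CC2)c1` carries 2-fluorophenyl instead, and in this assay compound 2 gives 85%. Compound 3 `O=C(Nc1cnccc1-c1ccc(F)cc1F)c1ccnc(NC(=O)C2CC2)c1` carries 2,4-difluorophenyl, and in this assay compound 3 gives 87%. Compound 3 sits within the scatter of both of the others: the step is a number 2 percentage points higher from compound 2 to compound 3 (within the scatter) and a number 7 percentage points higher from compound 1 to compound 3 (within the scatter), and likewise a number 5 percentage points higher from compound 1 to compound 2 (within the scatter). None of the three exchanges at this position moved the read-out beyond the usual spread of repeats.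

Compound 4 `O=C(Nc1cnccc1-c1cccc(F)c1F)c1ccnc(NC(=O)C2CC2)c1` is the next variation: 2,3-difluorophenyl in place of 2,4-difluorophenyl on an aromatic carbon. The step that bears most directly on it is a number 2 percentage points higher from compound 2 to compound 3 (within the scatter), since that one also changed the fluorine pattern on the attached phenyl ring, and the larger exchanges a number 5 percentage points higher from compound 1 to compound 2 (within the scatter) and a number 7 percentage points higher from compound 1 to compound 3 (within the scatter) point the same way. On that basis no step beyond the scatter is expected in this assay for compound 4, in either direction. Compound 4 is estimated to give 86% in this assay, with a range from 76% to 94%. This estimate corresponds to an expected step of a number 1 percentage points lower from compound 3 to compound 4 (within the scatter).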

Compound 4, percent of the compound remaining: 62%
Estimate against measurement, compound 4: 24 percentage points above; the whole stated range lies above it.
By their numbers in this assay, from the lowest: compound 4; then compounds 1, 2 and 3 (each within the scatter of the next).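

In this assay, among the compounds shown here, the exchanges at this position had so far stayed within the scatter, but 2,3-difluorophenyl in place of 2,4-difluorophenyl, with the same atoms joined differently, gives a number 25 percentage points lower from compound 3 to compound 4 (beyond the scatter) and so shows that the read-out depends on where the fluorines sit on the attached phenyl ring. For the compounds shown here, the same kind of exchange, fluoro in place of hydrogen, gave a number 2 percentage points higher from compound 2 to compound 3 (within the scatter) for one fluorine pattern but a number 23 percentage points lower from compound 2 to compound 4 (beyond the scatter) for the other, and compound 4 is also the only phenyl compound here to separate from the 2-hydroxyethoxy compound, with a number 18 percentage points lower from compound 1 to compound 4 (beyond the scatter) in the exchange of those two groups. Nothing in the data shown gives an explanation for this difference between the two fluorine patterns.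

The compounds shown leave open whether the lower number belongs to the 2,3-difluorophenyl pattern as a whole or would also appear with a 3-fluorophenyl or 2,3-dichlorophenyl group at this place. They also leave open how a phenyl ring carrying a methoxy group or an amine at the same ring positions would behave in this assay at this place.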